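Arylpiperazine amides of a phenylsuccinimide core against electroshock

A few compounds are considered here, and "the series" means these few. Any claim that something is new, unique, unknown or untested is made for them only; others in the source may bear on it.

Compound 1 `CC1(c2ccccc2)CC(=O)N(CC(=O)N2CCOCC2)C1=O`, compound 2 `CC1(c2ccccc2)CC(=O)N(CC(=O)N2CCN(c3cccc(C(F)(F)F)c3)CC2)C1=O` and compound 3 `Cc1cccc(N2CCN(C(=O)CN3C(=O)CC(C)(c4ccccc4)C3=O)CC2)c1` share the same core and differ only in the ring attached through the amide. In a functional assay on the whole organism (strain CD-1) with Mus musculus as the target, in the maximal electroshock model, with a stated time of 2 h (on this read-out higher numbers stand for an effect only at larger amounts of compound and lower numbers for an effect already at smaller amounts), compound 1 gives 300 mg/kg, compound 2 gives 300 mg/kg and compound 3 gives 300 mg/kg. Compound 3 thus stands level with compounds 1 and 2 at the digits shown, and the step of no change at the digits printed from compound 2 to compound 3 (within the scatter) lies within the scatter. Compound 4 `CC1(c2ccccc2)CC(=O)N(CC(=O)N2CCN(c3cccc(Cl)c3Cl)CC2)C1=O` carries 2,3-dichlorophenyl in place of 3-methylphenyl on an amine nitrogen in a ring. For the measured compounds named here, only the step from compound 2 to compound 3 bears on such a change on this ring nitrogen, and it showed nothing beyond the scatter, so the step expected in this assay is no change at the digits printed from compound 3 to compound 4 (within the scatter). Compound 4 is accordingly estimated at 300 mg/kg, within 100 mg/kg to 600 mg/kg.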

Compound 4, minimum effective dose: "not active" (no number reported)
No number was reported for compound 4; the estimate stays without a comparison.
By their numbers in this assay, from the lowest: compounds 1, 2 and 3 (each within the scatter of the next).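

For the compounds shown here, compound 4 is reported as not active in this assay, with no number, so no step from compound 3 to compound 4 can be read. The compounds shown leave open how far compound 4 stands from compound 3. No measurement shown here accounts for this result.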